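The compounds below may be only part of what the source reports. "The series", "measured", "known", "first", "only" and "open" are said of these compounds alone.

In an ADME assay on MRC5 cells (Homo sapiens), read by MTT assay, with a stated time of 72 h (on this read-out lower numbers stand for stronger inhibition and higher numbers for weaker inhibition), compound 1 `Cc1nc(N)c2c(-c3cccs3)cn([C@@H]3O[C@H](CO)[C@@H](O)[C@H]3O)c2n1` gives > 100000 nM, which is a limit and not a number. In this assay compound 2 `Cc1nc(N)c2c(-c3ccccc3)cn([C@@H]3O[C@H](CO)[C@@H](O)[C@H]3O)c2n1` gives > 100000 nM, which is also only a limit. Among the measured compounds shown here, compound 2 therefore has no number of its own, and the one other value beside it is no number either.

The next change leads to compound 3 `Cc1nc(N)c2c(-c3cc4ccccc4o3)cn([C@@H]3O[C@H](CO)[C@@H](O)[C@H]3O)c2n1`, with 1-benzofuran-2-yl in place of phenyl on an aromatic carbon.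

For the measured compounds named here, only one measured step bears on this change, the exchange of thiophen-2-yl for phenyl on that aromatic carbon: a step that the two limits leave unreadable from compound 1 to compound 2. The whole record so far is the limit of > 100000 nM in this assay, at which 2 of the 2 values shown sit. No size can be carried over from it, so no firm step can be expected in this assay. The most likely outcome is that compound 3 also reports a limit, and any readable number would be expected to lie towards stronger inhibition.

The expected move is an at least 1.2-fold lower number from compound 2 to compound 3 (0.09 log units; that floor lies within the scatter). Compound 3 is estimated at 80000 nM, within an expected range of 25000 nM to 100000 nM.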

Compound 3, half-maximal inhibitory concentration: 91800 nM
The estimate for compound 3 lay 1.1-fold (0.06 log units) below the measured number; the measured number falls inside the stated range.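

With 1-benzofuran-2-yl on this aromatic carbon of the five-membered ring, this assay yields the only readable number among the compounds shown, as compound 3 gives 91800 nM. Measured against the limits of the two single-ring compounds, this change gives an at least 1.0-fold lower number from compound 2 to compound 3 (0.03 log units; that floor lies within the scatter), and the exchange for thiophen-2-yl gives an at least 1.0-fold lower number from compound 1 to compound 3 (0.03 log units; that floor lies within the scatter), so both steps have only a floor and neither establishes stronger inhibition. The record at this position still consists mostly of limits: the limit of > 100000 nM in this assay, at which 2 of the 3 values shown sit.

The compounds shown leave open whether the readable number goes with the second aromatic ring of 1-benzofuran-2-yl or with its ring oxygen, a question that 2-naphthyl or 1-benzothiophen-2-yl on the same carbon would address. Also open, as far as these compounds go, is how a group of another kind on that carbon, such as an amine, a carboxylic acid or a longer alkyl chain, would read in this assay.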